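Swapping a Benzyl Substituent on a Weakly Cytotoxic Series

The compounds below may be only part of what the source reports. "The series", "measured", "known", "first", "only" and "open" are said of these compounds alone.

Compound 1 `Cc1cccc(Cn2cc(COc3ccc4c(=O)ccoc4c3)nn2)c1` was tested in a functional assay on SGC-7901 cells (Homo sapiens) for cytotoxicity, read by MTT assay, with a stated time of 48 h; on this read-out lower numbers stand for stronger inhibition and higher numbers for weaker inhibition. In this assay compound 1 gives only a limit, > 100000 nM, not a measured number. Compound 2 `O=c1ccoc2cc(OCc3cn(Cc4cccc(Br)c4)nn3)ccc12` differs from compound 1 by bromo in place of methyl on an aromatic carbon. In this assay compound 2 also gives only a limit, > 100000 nM. Between them lies a step that the two limits leave unreadable from compound 1 to compound 2; both values sit at the limit of > 100000 nM in this assay, at which 2 of the 2 values shown sit, so the size of that change cannot be read. Compound 3 `O=c1ccoc2cc(OCc3cn(Cc4ccccc4Cl)nn3)ccc12` carries the change (2-chlorophenyl in place of 3-methylphenyl on a saturated chain carbon bound to an aromatic nitrogen). Among the compounds with values here, no measured step bears on this change in a readable way, since the one comparison available stays at the limit. The expected step is therefore a step that the limit leaves unreadable from compound 1 to compound 3, meaning no change beyond the scatter that the numbers could show. Compound 3 is expected at 150000 nM, with a range from 50000 nM to 500000 nM, most probably reported again as a limit.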

Compound 3, half-maximal inhibitory concentration: > 100000 nM
Compound 3: a limit, no number; the forecaster's own chance of this, stated with the estimate: 80%; the middle value is on the limit's open side.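

Within the data shown here, compound 3 gives only a limit, as compound 1 and compound 2 do, so no step among the three can be read, because all of them rest at the same limit: the limit of > 100000 nM in this assay, at which 3 of the 3 values shown sit. What the compounds shown leave open is how strongly each one acts, and whether any other benzyl substituent would give a measured number.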